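Vero cytotoxicity notes: compound 3 to compound 4

The source may report more compounds than this note shows. Statements on the series, on what has been measured and on what is new or still open speak of the compounds shown alone.

Measured so far in an ADME assay on Vero cells (Chlorocebus sabaeus) for cytotoxicity, read by MTT assay, with a stated time of 24 h; a lower number here means that less compound is tolerated, a higher number that more compound is tolerated:
- compound 1, `COc1ccc(CNc2ccc3nc(N)nc(N)c3c2)cc1`, gives 147000 nM
- compound 2, `CCN(Cc1ccc(OC(F)(F)F)cc1)c1ccc2nc(N)nc(N)c2c1`, reaches only a limit of this assay at > 200000 nM
- compound 3, `Nc1nc(N)c2cc(NCc3ccc(OC(F)(F)F)cc3)ccc2n1`, gives 182000 nM

Compound 3 holds one of the two numbers in this assay; compound 1 lies within the scatter of it. Compound 2 sits at a limit, as shown by the limit of > 200000 nM in this assay, at which 1 of the 3 values shown sits. The two measured steps that lead to compound 3 are a 1.2-fold higher number from compound 1 to compound 3 (0.09 log units; within the scatter) and an at least 1.0-fold lower number from compound 2 to compound 3 (0.04 log units; that floor lies within the scatter), neither of them beyond the scatter.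

The next compound, compound 4, `CN(C)CCCOc1ccc(CNc2ccc3nc(N)nc(N)c3c2)cc1`, differs from compound 3 as follows: 3-(dimethylamino)propyl in place of trifluoromethyl on an oxygen on an aromatic ring. The step most comparable is the one at the same oxygen, a 1.2-fold higher number from compound 1 to compound 3 (0.09 log units; within the scatter), which changed the group on the oxygen and moved the number only within the scatter. Among the measured compounds shown here, no measured step covers a 3-(dimethylamino)propyl group, so the reading of compound 3 is the only anchor.

On that basis no step beyond the scatter is expected in this assay, and the step of a 1.2-fold lower number from compound 3 to compound 4 (0.08 log units; within the scatter) is the estimated outcome. Compound 4 is expected to give about 150000 nM, within a range of 60000 nM to 250000 nM.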

Compound 4, half-maximal cytotoxic concentration: > 200000 nM
Compound 4: only a limit was reported; the forecaster's own chance of this, stated with the estimate: 30%; middle value at least 1.3-fold (0.12 log units) from the limit.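

In this assay compound 4 gives > 200000 nM, which is a limit and not a number. Among the compounds shown here, the oxygen on an aromatic ring had so far carried only methyl and trifluoromethyl; with 3-(dimethylamino)propyl, a larger chain that brings in a nitrogen and a hydrogen-bond acceptor, the reading shows no drop, with an at least 1.0-fold higher number from compound 3 to compound 4 (0.04 log units; that floor lies within the scatter) and an at least 1.3-fold higher number from compound 1 to compound 4 (0.13 log units; that floor lies within the scatter), so at this position the change from a small group to this chain leaves no step beyond the scatter that can be stated. What this position can show in this read-out is therefore capped, and the series now has a second compound there: the limit of > 200000 nM in this assay, at which 2 of the 4 values shown sit.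

As far as these compounds go, whether the tolerance at this oxygen holds for other groups stays open, for example a carboxylic acid, a primary amine at the end of the propyl chain, or a chain closed into a morpholine ring. Also open, from the compounds shown here alone, is whether 3-(dimethylamino)propyl gives the same picture when the nitrogen on the aromatic ring carries ethyl in place of hydrogen, as that nitrogen does in compound 2.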